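A Methoxy in Place of Methyl on Compound 1

The source may hold more compounds than are shown below. What is called first, only, known or untested is meant among the compounds shown, and "the series" means these compounds.

Compound 1 `C#CCNC1CCc2c(SCc3ccc(C)cc3)cccc21` gives the lowest of the two numbers measured in an ADME assay on isolated protein for inhibition of Amine oxidase [flavin-containing] B (Homo sapiens) (on this read-out lower numbers stand for stronger inhibition and higher numbers for weaker inhibition), with 320 nM. Its nearest neighbour is compound 2 `C#CCNC1CCc2c(SCc3cccc(Cl)c3)cccc21`, which in this assay gives 1090 nM; the step of a 3.4-fold higher number from compound 1 to compound 2 (0.53 log units; beyond the scatter) comes with 3-chlorophenyl in place of 4-methylphenyl on a saturated chain carbon bound to a sulfur. Compound 3 `C#CCNC1CCc2c(SCc3cccc(Br)c3)cccc21` reaches only a limit of this assay, reported as > 100000 nM, so that the limit of > 100000 nM in this assay, at which 1 of the 3 values shown sits, holds for it. The steps of an at least 310-fold higher number from compound 1 to compound 3 (2.49 log units; beyond the scatter) and an at least 91-fold higher number from compound 2 to compound 3 (1.96 log units; beyond the scatter) are large, the latter with bromo in place of chloro on an aromatic carbon.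

Compound 4 `C#CCNC1CCc2c(SCc3ccc(OC)cc3)cccc21` differs from compound 1 by methoxy in place of methyl on an aromatic carbon. For the measured compounds named here, none of the measured steps exchanges methyl for methoxy; the two from compound 1 move the group and bring a halogen, and the third swaps halogens, so they bear on the change only indirectly. A step no larger than modest is therefore expected in this assay, if anything towards a higher number. Compound 4 is estimated at 550 nM, between 150 nM and 2500 nM, meaning an expected step of a 1.7-fold higher number from compound 1 to compound 4 (0.24 log units; within the scatter).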

Compound 4, half-maximal inhibitory concentration: 3960 nM
Compound 4: middle estimate off by 7.2-fold (0.86 log units), on the low side; measured number outside the range, above it.
By their numbers in this assay, from the lowest: compound 1; then compound 2; then compound 4. At a limit, above all of these: compound 3.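

In this assay, exchanging methyl for methoxy on an aromatic carbon, para to a large group, proves to be no minor edit (a 12-fold higher number from compound 1 to compound 4 (1.09 log units; beyond the scatter)). This is the first step shown that leaves the place on the ring unchanged and alters only the group that sits there, whereas the earlier steps from compound 1 changed the place and brought in a halogen together. It therefore shows that this place alone is sensitive to the change of group, although nothing measured here gives a reason for the step.

From the compounds shown here alone, it remains open whether a hydroxyl, an ethyl or an amine in the same place would stay close to compound 1 or follow compound 4. Whether methoxy elsewhere on this ring would give a step of similar size is also unresolved.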